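This account rests on a few compounds, and the source may have more. Where it says the series, first, only, none or still open, it means among the compounds named here.

In a functional assay on PBMC cells (Homo sapiens) for inhibition, read by HTRF, with stated times of 15 min and 24 h (on this read-out lower numbers stand for stronger inhibition and higher numbers for weaker inhibition), two compounds built on the shared core have been measured so far. Compound 1 `O=C(Nc1ccc2c(c1)B(O)OC2)c1ccccc1C(F)(F)F` gives 2100 nM. Compound 2 `O=C(Nc1ccc2c(c1)B(O)OC2)c1ccccc1Cl` gives > 100000 nM, which is a limit of the assay and not a number. Compound 2 therefore stands at the limit of > 100000 nM in this assay, at which 1 of the 2 values shown sits.

Compound 3 `COc1ccccc1C(=O)Nc1ccc2c(c1)B(O)OC2` carries a single change from compound 2: methoxy in place of chloro on an aromatic carbon. This places methoxy in place of chloro on an aromatic carbon, ortho to a large group. Going by the values given here, one measured step bears on this change, an at least 47-fold higher number from compound 1 to compound 2 (1.67 log units; beyond the scatter). That step is large and beyond the scatter, and it also replaces one group with another on an aromatic carbon. It shows that exchanging a single group on the shared core can move the read-out a long way in this assay. A step towards a lower number, meaning stronger inhibition, is therefore expected, although compound 3 may also remain at the limit. The expected step is an at least 5.0-fold lower number from compound 2 to compound 3 (0.69 log units; beyond the scatter). For compound 3, the estimated value is 20000 nM, with an expected range of 4000 nM to 80000 nM.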

Compound 3, half-maximal inhibitory concentration: > 100000 nM
Compound 3 was reported as a limit (the forecaster's own chance of this, stated with the estimate: 40%); at least 5.0-fold (0.69 log units) between middle value and limit.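

In this assay, going from trifluoromethyl to methoxy, ortho to a large group, gives an at least 47-fold higher number from compound 1 to compound 3 (1.67 log units; beyond the scatter), so chloro is no longer the only replacement for trifluoromethyl at this position that ends at a limit. Of the three groups shown here, only trifluoromethyl gives a number, with compound 1 at 2100 nM, and adding a hydrogen-bond acceptor in the form of methoxy does not bring a value within the range of this assay. Compound 2 and compound 3 both stand at a limit and not at a number, and the step between them cannot be read: the limit of > 100000 nM in this assay, at which 2 of the 3 values shown sit.

Going by these compounds, how far compound 2 and compound 3 lie past that limit remains open, and with it any order between chloro and methoxy. Also open, on these data alone, is whether another group at this place, such as trifluoromethoxy, a nitrile, an ethyl group or an amine, would give a number as trifluoromethyl does, or whether compound 1 stands alone among such replacements on the shared core.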